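The compounds below may be only part of what the source reports. "The series", "measured", "known", "first", "only" and "open" are said of these compounds alone.

Compound 1 `Cc1cc(O)cc(-c2nn(CC#N)cc2-c2ccnc(-c3ccc(Oc4ccccc4)cc3)c2)c1`: in a functional assay on UACC-257 cells (Homo sapiens) for inhibition, read by sulforhodamine B assay, with a stated time of 48 h (on this read-out higher numbers stand for lower toxicity in this test and lower numbers for higher toxicity in this test), compound 1 gives 31700 nM.
Compound 2 `COc1cc(C)cc(-c2nn(CC#N)cc2-c2ccnc(-c3ccc(N(C)C)cc3)c2)c1`: in this assay compound 2 is reported only as a limit, > 100000 nM.

Compound 2 therefore sits at the limit of > 100000 nM in this assay, at which 1 of the 2 values shown sits, and no number for it is known. Compound 3 `Cc1cc(O)cc(-c2nn(CC#N)cc2-c2ccnc(-c3ccc(N(C)C)cc3)c2)c1` differs from compound 2 by hydrogen in place of methyl on an oxygen on an aromatic ring. For the measured compounds named here, no measured pair shows this change on its own, so the size of the step cannot be read from the data. Compound 1 carries the same hydroxy group and gives a number rather than a limit. Compound 3 is expected to land near 80000 nM, in the range 25000 nM to 300000 nM, with an estimated step of an at least 1.2-fold lower number from compound 2 to compound 3 (0.09 log units; that floor lies within the scatter), and a fair chance that only a limit is reported again.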

Compound 3, concentration lethal to 50% of the cells: > 100000 nM
Compound 3: no number, only a limit; the forecaster's own chance of this, stated with the estimate: 50%; middle value at least 1.2-fold (0.09 log units) away from the limit.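

Compound 3 and compound 2 are both reported only as limits, so the step between them cannot be read, and the swap of methoxy for hydroxy has no measurable size here. With the hydroxy group held constant, dimethylamino in place of phenoxy on an aromatic carbon gives an at least 3.1-fold higher number from compound 1 to compound 3 (0.49 log units; beyond the scatter) in this assay, so the hydroxy group alone does not bring compound 3 down to the level of compound 1. Most of the compounds now sit at the top of the readable range: the limit of > 100000 nM in this assay, at which 2 of the 3 values shown sit.

Still open, on these data alone, is how far methoxy to hydroxy moves the number when phenoxy is present. Also open, as far as these compounds go, is whether a carboxylic acid or a primary amine on that aromatic carbon would give a number rather than a limit.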